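Working notes: cytotoxicity across four related compounds

This account rests on a few compounds, and the source may have more. Where it says the series, first, only, none or still open, it means among the compounds named here.

Measured so far in an ADME assay on S2 cells (Drosophila melanogaster) for cytotoxicity, read by MTT assay; on this read-out lower numbers stand for an effect already at smaller amounts and higher numbers for an effect only at larger amounts of compound:
compound 1 `COC(=O)/C=C/[C@H]1C[C@@H](O)[C@@H](O)C1`, > 350000 nM
compound 2 `CN(C)C(=O)/C=C/[C@H]1C[C@@H](O)[C@@H](O)C1`, > 250000 nM
compound 3 `CCCCNC(=O)/C=C/[C@H]1C[C@@H](O)[C@@H](O)C1`, > 250000 nM

Compound 1 gives only a limit of the assay, > 350000 nM. Compound 2 likewise gives only a limit, > 250000 nM. Compound 3 stands at a limit as well, > 250000 nM, and the two other values are limits too, so no ranking among the three is possible. The steps are accordingly unreadable: a step that the two limits leave unreadable from compound 1 to compound 2, a step that the two limits leave unreadable from compound 1 to compound 3, a step that the two limits leave unreadable from compound 2 to compound 3. The reason is the limit of > 250000 nM in this assay, at which 2 of the 3 values shown sit, together with the limit of > 350000 nM in this assay, at which 1 of the 3 values shown sits.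

Compound 4 is `O=C(O)/C=C/[C@H]1C[C@@H](O)[C@@H](O)C1`. From compound 3 it differs by hydroxy in place of butylamino on a carbonyl carbon. Going by the values given here, no measured step bears on this change with a readable size, since every step so far ends at a limit. The only expectation the data support is that compound 4 also reaches no numerical value in this assay. The step from compound 3 to compound 4 is therefore estimated as a step that the limit leaves unreadable from compound 3 to compound 4. Compound 4 is expected at about 300000 nM, with a range from 150000 nM to 1000000 nM.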

Compound 4, half-maximal effective concentration: > 350000 nM
Compound 4 gave a limit, no number; the forecaster's own chance of this, stated with the estimate: 80%; middle value at least 1.1-fold (0.06 log units) from the limit.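

Compound 4, like compound 1, gives only a limit in this assay, so no new step can be read among the four compounds: the limit of > 350000 nM in this assay, at which 2 of the 4 values shown sit. Compound 2 and compound 3 stand at the other limit: the limit of > 250000 nM in this assay, at which 2 of the 4 values shown sit. The compounds shown leave open whether any change on the carbonyl carbon alters cytotoxicity, and at what concentration any of the four would show an effect.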